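This account rests on a few compounds, and the source may have more. Where it says the series, first, only, none or still open, it means among the compounds named here.

Measured so far in a physicochemical assay for solubility, in phosphate buffer, with a stated time of 18 h; on this read-out higher numbers stand for higher solubility and lower numbers for lower solubility:

- Compound 1 `N#Cc1c(N)nc2nc(C3CC3)ncc2c1N`: 23000 nM
- Compound 2 `CCCCc1nc(C(C)(C)C)nc2nc(N)c(C#N)c(N)c12`: 6000 nM

Of these two, compound 2 stands lowest at 6000 nM, and its gap to compound 1 at 23000 nM lies beyond the scatter. The two compounds differ in more than one place, so that gap cannot be tied to any single change.

Compound 3 `CC(C)(C)c1nc(-c2nccs2)c2c(N)c(C#N)c(N)nc2n1` has not yet been measured. It keeps the tert-butyl group of compound 2 but carries 1,3-thiazol-2-yl in place of butyl on an aromatic carbon, next to the ring nitrogen: 1,3-thiazol-2-yl in place of butyl on an aromatic carbon. Among the measured compounds shown here, no measured pair here isolates such a swap, so the data offer no direct guide to its size or direction.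

In this assay, the expectation is therefore of no step beyond the scatter, though a wide margin on either side is warranted. The expected change is a 1.2-fold higher number from compound 2 to compound 3 (0.07 log units; within the scatter). The estimated value for compound 3 is 7000 nM, with an expected range from 2000 nM to 20000 nM.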

Compound 3, solubility: < 1500 nM
Compound 3 was reported as a limit (the forecaster's own chance of this, stated with the estimate: 10%); middle value at least 4.6-fold (0.66 log units) away from the limit.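

In this assay, among the compounds shown here, putting 1,3-thiazol-2-yl in place of butyl on the aromatic carbon next to the ring nitrogen gives an at least 4.0-fold lower number from compound 2 to compound 3 (0.60 log units; beyond the scatter), the first step in this set that ties a change in the read-out to a single place. Compound 3 is recorded in this assay only as a limit, < 1500 nM, and not as a number. The step therefore fixes a direction and a smallest size for this swap, but its full size stays unknown because the value of compound 3 rests on a limit: the limit of < 1500 nM in this assay, at which 1 of the 3 values shown sits.

The compounds shown leave open whether the fall follows the aromatic ring as such or its nitrogen and sulfur atoms, which a phenyl ring on the same carbon would help to separate. Also open, going by these compounds, is how a shorter chain such as methyl or a polar group such as an amine would read at this carbon, and compound 1 cannot settle this, since it differs from compound 2 and compound 3 in more than one place.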